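The source may hold more compounds than are shown below. What is called first, only, known or untested is meant among the compounds shown, and "the series" means these compounds.

Measured compounds:
compound 1 `NC(=O)c1ccc(Cn2ncc3c(Nc4ccc(OC(F)(F)F)cc4)ncnc32)cc1` — > 10000 nM
compound 2 `CC(C)(C)n1ncc2c(Nc3ccc(OC(F)(F)F)cc3)ncnc21` — 7300 nM
compound 3 `FC(F)(F)Oc1ccc(Nc2ncnc3c2cnn3C2CCCCC2)cc1` — 9300 nM

In an ADME assay on BaF3 cells (Mus musculus) for cytotoxicity (a lower number here means that less compound is needed, a higher number that more compound is needed for the effect), compound 1 gives only a limit, > 10000 nM; this is a limit of the assay, not a number (the limit of > 10000 nM in this assay, at which 1 of the 3 values shown sits). Compound 2 gives 7300 nM and compound 3 gives 9300 nM; the step between them, a 1.3-fold higher number from compound 2 to compound 3 (0.11 log units; within the scatter), lies within the scatter, so the two numbers are not told apart. The steps from the limit, an at least 1.3-fold lower number from compound 1 to compound 2 (0.13 log units; that floor lies within the scatter) and an at least 1.0-fold lower number from compound 1 to compound 3 (0.03 log units; that floor lies within the scatter), have floors that also lie within the scatter and set no real size.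

The next compound, compound 4 `CCCn1ncc2c(Nc3ccc(OC(F)(F)F)cc3)ncnc21`, changes the group on the aromatic nitrogen of compound 3: propyl in place of cyclohexyl on an aromatic nitrogen. Among the measured compounds shown here, the one measured step that bears on such a swap of a saturated carbon group at that position is a 1.3-fold higher number from compound 2 to compound 3 (0.11 log units; within the scatter), which stayed within the scatter; the steps from compound 1 give only floors. On that basis a step of size beyond the scatter is not expected for compound 4 in either direction, and compound 4 is expected to give 8000 nM, within 4000 nM to 16000 nM. The step this estimate means, a 1.2-fold lower number from compound 3 to compound 4 (0.07 log units; within the scatter), is expected to stay within the scatter, with a fair chance that the assay again returns only a limit.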

Compound 4, half-maximal effective concentration: 6600 nM
For compound 4 the middle estimate is 1.2-fold (0.08 log units) above the measured one; the measured number falls inside the stated range.
By their numbers in this assay, from the lowest: compounds 4, 2 and 3 (each within the scatter of the next). At a limit, above all of these: compound 1.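

With propyl, an open chain now stands at this place, on an aromatic nitrogen of the five-membered ring, alongside the tert-butyl and cyclohexyl groups: a 1.4-fold lower number from compound 3 to compound 4 (0.15 log units; within the scatter) and a 1.1-fold lower number from compound 2 to compound 4 (0.04 log units; within the scatter), so this assay does not tell these three saturated carbon groups apart. Losing the six-membered ring of cyclohexyl therefore brings no step beyond the scatter, and neither ring nor branching is needed for a measurable number in this series, while the comparison with the 4-carbamoylbenzyl group stays weak, with an at least 1.5-fold lower number from compound 1 to compound 4 (0.18 log units; that floor lies within the scatter). Compound 1 remains a limit of the assay, not a number: the limit of > 10000 nM in this assay, at which 1 of the 4 values shown sits.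

Open, as far as these compounds go, is whether any group on this nitrogen gives a step beyond the scatter, for instance a longer chain such as octyl, a chain ending in an amine or a carboxylic acid, or a plain methyl. Also open, from the compounds shown here alone, is whether the 4-carbamoylbenzyl group truly differs from the three saturated carbon groups, and whether the flat result holds when the rest of the shared core is changed.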